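Cyclopropyl in place of 4-methylphenyl on a carbonyl carbon

The source may hold more compounds than are shown below. What is called first, only, known or untested is meant among the compounds shown, and "the series" means these compounds.

Compound 1 `N#Cc1cn(C(=O)C2CC2)c2ncccc12` gives 6.8 h
Compound 2 `CCOC(=O)c1cn(C(=O)c2cccc(C)c2)c2ncccc12` gives 3.5 h
Compound 3 `CCOC(=O)c1cn(C(=O)c2ccc(C)cc2)c2ncccc12` gives 4.3 h

These numbers come from a physicochemical assay for metabolic stability, read by spectrophotometry, in phosphate buffer, at 25 degrees C, at pH 7.3 (on this read-out lower numbers stand for a shorter-lived compound and higher numbers for a longer-lived compound), and lie close together. Compound 3 stands within the scatter of both compound 1 and compound 2, so no order can be read among the three.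

The change cyclopropyl in place of 4-methylphenyl on a carbonyl carbon leads to compound 4 `CCOC(=O)c1cn(C(=O)C2CC2)c2ncccc12` with cyclopropyl in place of 4-methylphenyl on a carbonyl carbon. For the measured compounds named here, only one measured step links two close relatives: a 1.2-fold higher number from compound 2 to compound 3 (0.09 log units; within the scatter) stays within the scatter. That step exchanges 3-methylphenyl for 4-methylphenyl, so it bears only indirectly on losing that group altogether. Compound 1 carries the same cyclopropyl on a carbonyl carbon and gives 6.8 h but differs from compound 4 elsewhere, so it supports no more than a slight expected rise. The estimated move is a 1.4-fold higher number from compound 3 to compound 4 (0.14 log units; within the scatter) and no step beyond the scatter is expected. In this assay compound 4 is estimated at 6 h with an expected range of 3.3 h to 11 h around that value.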

Compound 4, half-life: 14.4 h
For compound 4 the middle estimate is 2.4-fold (0.38 log units) below the measured one, and the stated range ends below it.
By their numbers in this assay, from the lowest: compounds 2, 3 and 1 (each within the scatter of the next); then compound 4.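

In this assay, the group on the carbonyl carbon proves able to shift the half-life beyond the scatter: cyclopropyl in place of 4-methylphenyl gives (a 3.3-fold higher number from compound 3 to compound 4 (0.52 log units; beyond the scatter)), and cyclopropyl in place of 3-methylphenyl gives (a 4.1-fold higher number from compound 2 to compound 4 (0.61 log units; beyond the scatter)), whereas exchanging the two methylphenyl groups had stayed within the scatter. The substituent on the aromatic carbon also proves to matter once cyclopropyl is held constant, with ethoxycarbonyl in place of cyano giving (a 2.1-fold higher number from compound 1 to compound 4 (0.33 log units; beyond the scatter)). Nothing in the available data accounts for either rise.

The compounds shown leave open whether the higher numbers follow from cyclopropyl itself or from the absence of a methylphenyl group, a question that an isopropyl, a cyclobutyl or an unsubstituted phenyl on the carbonyl carbon would address. They also leave open how a carboxylic acid or a primary amide would compare with ethoxycarbonyl on the aromatic carbon.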